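The source may report more compounds than this note shows. Statements on the series, on what has been measured and on what is new or still open speak of the compounds shown alone.

Measured in a functional assay on cells (Tumor Cell line, Homo sapiens) for cytotoxicity; a higher number here means a weaker inhibitor of growth, a lower number a stronger inhibitor of growth:
- compound 1 `Cc1cc(C)c2c(O)cc(-c3ccc(Cl)cc3)nc2n1`: 19500 nM
- compound 2 `Oc1cc(-c2ccc(Cl)cc2)nc2ncccc12`: 38900 nM
- compound 3 `Cc1ccnc2nc(-c3ccc(F)cc3)cc(O)c12`: 38000 nM

Compound 3 lies within the usual scatter of both compound 1 and compound 2, so these numbers do not separate from one another. Compound 4 `Cc1ccnc2nc(-c3ccc(Cl)cc3)cc(O)c12` is still unmeasured. It differs from compound 3 by chloro in place of fluoro on an aromatic carbon. Among the compounds with values here, no measured pair isolates this swap, so the guide is loose: compound 1 and compound 2 both carry chloro, and their values stay within the scatter of compound 3. No shift beyond the scatter is therefore expected in this assay. The estimated step is small, a 1.3-fold lower number from compound 3 to compound 4 (0.12 log units; within the scatter). The estimate for compound 4 is 29000 nM, with an expected range from 14000 nM to 60000 nM.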

Compound 4, concentration for 50% growth inhibition: 5130 nM
Beside the measured number, compound 4's estimate is 5.7-fold (0.75 log units) above it; measured number below the stated range.
By their numbers in this assay, from the lowest: compound 4; then compounds 1, 3 and 2 (each within the scatter of the next).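

In this assay, chloro in place of fluoro on an aromatic carbon, para to a large group, gives a 7.4-fold lower number from compound 3 to compound 4 (0.87 log units; beyond the scatter) and so shows that this position responds to which halogen it carries. The methyl groups on the core matter too: methyl in place of hydrogen gives a 7.6-fold lower number from compound 2 to compound 4 (0.88 log units; beyond the scatter) and hydrogen in place of methyl gives a 3.8-fold lower number from compound 1 to compound 4 (0.58 log units; beyond the scatter). Among these chloro compounds, the lowest number therefore goes with one methyl, rather than none or two.

Nothing measured here explains these shifts. As far as these compounds go, whether bromo or methoxy at the halogen's place would lower the number further stays open.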